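The compounds below may be only part of what the source reports. "The series", "measured", "known", "first", "only" and "open" are said of these compounds alone.

The shared core of compound 1 `CN/C(C)=N/C1=Nc2ccccc2CS1` carries a methylamino group on the amidine-like arm, and in a functional assay (strain Wistar) with Rattus norvegicus as the target, read by LDH release (a higher number here means that more compound is needed for the effect, a lower number that less compound is needed), compound 1 gives 0.01 uM. Among the measured compounds shown here, that is the only number in this set: a second member, compound 2 `CCCNC(=S)NC1=Nc2ccccc2CS1`, which bears a thiourea in place of that arm, is recorded in this assay as "not active" (no number reported), with no number to set beside compound 1. Compound 1 therefore stands alone as the single measured point of reference.

Compound 3 `C/C(=N\C1=Nc2ccccc2CS1)N(C)C` has not yet been measured. Relative to compound 1 it differs by methyl in place of hydrogen on an amine nitrogen. For the measured compounds named here, no measured pair shows what this change does here, so the expectation rests on the single point of compound 1. The step of a 3.0-fold higher number from compound 1 to compound 3 (0.48 log units; beyond the scatter) is expected to be modest, with somewhat more compound needed, though a change within the scatter would not be surprising. On that basis compound 3 is expected to give about 0.03 uM, within a range from 0.005 uM to 0.2 uM.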

Compound 3, minimum effective concentration: 0.1 uM
Beside the measured number, compound 3's estimate is 3.3-fold (0.52 log units) below it; the range from low to high includes it.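

Replacing methylamino with dimethylamino gives a 10-fold higher number from compound 1 to compound 3 (1.00 log units; beyond the scatter) in this assay, the first measured sign that this amine nitrogen is sensitive to substitution: one added methyl means clearly more compound is needed for the effect. The hydrogen on that nitrogen is still not essential for activity, since compound 3, which lacks it, gives a measurable 0.1 uM. No information is available on why this single methyl shifts the number by this much.

Going by these compounds, it remains open whether an ethyl group or a longer chain on this nitrogen would raise the number further, or whether a ring amine such as pyrrolidine would be tolerated. A plain amino group at the same place could also show whether the number falls when the remaining methyl is removed.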